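The compounds below may be only part of what the source reports. "The series", "measured", "known", "first", "only" and "open" are said of these compounds alone.

Notes on the series. In a functional assay on HL-60 cells (Homo sapiens) for cytotoxicity, read by MTT assay, with a stated time of 48 h (on this read-out higher numbers stand for weaker inhibition and lower numbers for stronger inhibition), compound 1 `CCOC(=O)[C@@H]1C[C@@]23CN(C)C[C@@H](CCC4=C2[C@@H]1CC4=O)C31CC[C@](CC)(OC)OC1` gives only a limit of the assay, > 40000 nM. Compound 2 `CCOC(=O)[C@@H]1C[C@@]23CN(C)C[C@@H](CCC4=C2[C@H]1CC4=O)C31CC[C@](CC)(OC)OC1` likewise returns only a limit in this assay, > 40000 nM. Compound 3 `CCO[C@@]1(CC)CCC2(CO1)[C@@H]1CCC3=C4[C@@H](CC3=O)[C@H](C(=O)OC)C[C@@]42CN(C)C1` also stops at a limit in this assay, > 40000 nM. The step that the two limits leave unreadable from compound 1 to compound 2 cannot be read; this rests on the limit of > 40000 nM in this assay, at which 3 of the 3 values shown sit, and on (the fact that one of compounds 1 and 2 is drawn with a defined configuration and the other without, at the place where they differ). Within the data shown here, compound 1 thus stands nowhere on a measurable scale: every value shown is a limit, and no step in the set has a size.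

Compound 4 `CC[C@]1(OC)CCC2(CO1)[C@@H]1CCC3=C4[C@H](CC3=O)[C@H](C(=O)OC)C[C@@]42CN(C)C1` differs from compound 1 by hydrogen in place of methyl on a saturated chain carbon bound to an oxygen next to a carbonyl group. No measured step bears on this change: the only step shown, from compound 1 to compound 2, is unreadable, and compound 3, which already carries a methoxycarbonyl group, gives only a limit. Nothing in the data points to a change in this assay beyond the scatter in either direction, and the most likely outcome is another limit. Compound 4 is therefore expected to sit at about 60000 nM, with a range of 20000 nM to 200000 nM. The step that the limit leaves unreadable from compound 1 to compound 4 is expected to be small and of no readable direction.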

Compound 4, half-maximal inhibitory concentration: > 40000 nM
Compound 4: a limit, no number; the forecaster's own chance of this, stated with the estimate: 80%; the middle value does not contradict the limit.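

Compound 4 also returns only a limit in this assay, > 40000 nM, so the step from compound 1 to compound 4 cannot be read. The compounds shown leave open whether ethoxycarbonyl to methoxycarbonyl, or any difference in configuration, shifts cytotoxicity at all on the shared core.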